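The compounds below may be only part of what the source reports. "The series", "measured", "known", "first", "only" and "open" are said of these compounds alone.

Compound 3 `C/C=C/C(=O)Nc1cccc(Cn2nc(-c3ccc(Oc4ccccc4)cc3)cc2C(=O)OCC)c1` carries an amide built from a prop-1-en-1-yl group on the carbonyl carbon. In a functional assay on Z-138 cells (Homo sapiens) for inhibition, read by luminescence and CellTiter-Glo, with a stated time of 72 h (on this read-out higher numbers stand for weaker inhibition and lower numbers for stronger inhibition), compound 3 gives 8900 nM, the higher of the two numbers measured here. Compound 1 `CCOC(=O)c1cc(-c2ccc(Oc3ccccc3)cc2)nn1Cc1cccc(NC(=O)CCl)c1`, bearing a chloromethyl on that same carbonyl carbon, gives 400 nM in this assay, and the change from compound 1 to compound 3 reads a 22-fold higher number from compound 1 to compound 3 (1.35 log units; beyond the scatter). Compound 2 `C/C=C/C(=O)Nc1ccc(Cn2nc(-c3ccc(Oc4ccccc4)cc3)cc2C(=O)OCC)cc1`, in which the amide sits at the other position of the phenyl, reaches only the limit of this assay, > 60000 nM, so the limit of > 60000 nM in this assay, at which 1 of the 3 values shown sits, applies to it. Moving the amide back gives an at least 6.7-fold lower number from compound 2 to compound 3 (0.82 log units; beyond the scatter), and compound 1 to compound 2 is an at least 150-fold higher number from compound 1 to compound 2 (2.17 log units; beyond the scatter).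

Compound 4 `C=CC(=O)Nc1cccc(Cn2nc(-c3ccc(Oc4ccccc4)cc3)cc2C(=O)OCC)c1` differs from compound 3 only in the acyl group: vinyl in place of prop-1-en-1-yl on a carbonyl carbon. Among the compounds with values here, no measured pair tests this exact change; the one step on the carbonyl carbon, compound 1 to compound 3, was large, showing that the group here matters. Compound 4 is therefore expected to land at 1500 nM in this assay, within 300 nM to 8000 nM, a step of a 5.9-fold lower number from compound 3 to compound 4 (0.77 log units; beyond the scatter) from compound 3.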

Compound 4, half-maximal inhibitory concentration: 7800 nM
Compound 4: middle estimate off by 5.2-fold (0.72 log units), on the low side; the range from low to high includes it.
By their numbers in this assay, from the lowest: compound 1; then compounds 4 and 3 (each within the scatter of the next). At a limit, above all of these: compound 2.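

In this assay, the step of a 1.1-fold lower number from compound 3 to compound 4 (0.06 log units; within the scatter) is within the scatter, so vinyl and prop-1-en-1-yl on this carbonyl carbon cannot be told apart. The step of a 20-fold higher number from compound 1 to compound 4 (1.29 log units; beyond the scatter), for vinyl in place of chloromethyl, shows that the large gap to compound 1 is not peculiar to prop-1-en-1-yl, as it now appears with both groups that carry a double bond. The step of an at least 7.6-fold lower number from compound 2 to compound 4 (0.88 log units; beyond the scatter) rests on a limit of the assay and not on a number: the limit of > 60000 nM in this assay, at which 1 of the 4 values shown sits.

The compounds shown leave open how a bromomethyl or an ethynyl group on this carbonyl carbon would read against chloromethyl and vinyl. They also do not show why chloromethyl stands apart from the other two groups.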